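The source may report more compounds than this note shows. Statements on the series, on what has been measured and on what is new or still open speak of the compounds shown alone.

Measured so far in an ADME assay on the whole organism with Oryza sativa as the target, tested at 1 uM; a lower number here means a stronger effect, a higher number a weaker effect of the compound at the concentration tested:

compound 1, `CCc1ccccc1NC(=O)N[C@H](C)c1ccccc1`, gives 100%
compound 2, `CCCc1ccc(NC(=O)N[C@H](C)c2ccccc2)cc1`, gives 31%
compound 3, `CCCc1ccc(NC(=O)N[C@@H](C)c2ccccc2)cc1`, gives 76%

Compound 3 stands second highest of the three values, between compound 1 and compound 2. For the measured compounds named here, the only step so far within a single change is a number 45 percentage points higher from compound 2 to compound 3 (beyond the scatter), a large rise that rests on (the fact that compounds 2 and 3 differ only in the configuration as drawn).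

Compound 4, `CC(=O)c1ccc(NC(=O)N[C@@H](C)c2ccccc2)cc1`, carries the same configuration as compound 3 and differs from it by acetyl in place of propyl on an aromatic carbon. Going by the values given here, no measured step touches this kind of change: the one step on record swaps configuration alone, and compound 1 differs from the others in more than one place, so its value is only a point of comparison, not a guide. The step from compound 3 to compound 4 is therefore open in direction, and nothing in the data argues for a change beyond the scatter. Compound 3 is taken as the anchor, and compound 4 is expected to give about 75% in this assay, with a broad range from 45% to 100%; the expected step is a number 1 percentage points lower from compound 3 to compound 4 (within the scatter).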

Compound 4, a percentage reported as activity, at one concentration (the size of the read-out at that concentration, not a potency): 99%
Compound 4: middle estimate off by 24 percentage points, on the low side; low and high end bracket the measured number.
By their numbers in this assay, from the lowest: compound 2; then compound 3; then compounds 4 and 1 (each within the scatter of the next).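

In this assay, replacing propyl with acetyl on an aromatic carbon para to a large group gives a number 23 percentage points higher from compound 3 to compound 4 (beyond the scatter), so this position responds to the group it carries and the effect weakens with acetyl. For the compounds shown here, until now the only readable step was a change of configuration; here the configuration stays as drawn, and a change of group alone moves the number beyond the scatter. Acetyl brings a hydrogen-bond acceptor and a double bond outside aromatic rings that propyl lacks, but no available measurement bears on why the number rises.

As far as these compounds go, it remains open whether the same exchange would have a similar effect in the configuration of compound 2. From the compounds shown here alone, how an amine, a carboxylic acid or a longer chain at this position would read in this assay also remains open.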